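This account rests on a few compounds, and the source may have more. Where it says the series, first, only, none or still open, it means among the compounds named here.

Three compounds of the series share one core and differ only in the group on an oxygen on an aromatic ring. Compound 1 `FC(F)(F)c1cccnc1N1CCC(NC(=S)Nc2cccnc2)CC1` reports only a limit in an assay on membranes from brain for binding affinity to Lysophosphatidylserine lipase ABHD12 (Mus musculus), read by fluorescence, with a stated time of 20 min (on this read-out higher numbers stand for weaker inhibition and lower numbers for stronger inhibition), giving > 5000 nM. Compound 2 `S=C(Nc1cccnc1)NC1CCN(c2cc(OC3CCCCC3)ccn2)CC1` gives 3400 nM in this assay, and compound 3 `S=C(Nc1cccnc1)NC1CCN(c2cc(OCC3CC3)ccn2)CC1` gives 4700 nM. The step of a 1.4-fold higher number from compound 2 to compound 3 (0.14 log units; within the scatter) leaves compound 3 and compound 2 within the scatter of each other, so the two numbers are not separated. Within the data shown here, the limit of > 5000 nM in this assay, at which 1 of the 3 values shown sits, for compound 1 adds no measured step. Compound 4 `COc1ccc(Oc2ccnc(N3CCC(NC(=S)Nc4cccnc4)CC3)c2)cc1` differs from compound 3 by 4-methoxyphenyl in place of cyclopropylmethyl on an oxygen on an aromatic ring. Among the measured compounds shown here, only the step from compound 2 to compound 3 bears on a change at this oxygen, and it was within the scatter; no measured step at this place reaches beyond it. Compound 4 is therefore expected to stay near compound 3, with the expected step of a 1.3-fold lower number from compound 3 to compound 4 (0.13 log units; within the scatter) lying within the scatter, while a limit remains possible. The estimate for compound 4 in this assay is 3500 nM, with a range from 900 nM to 9000 nM.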

Compound 4, half-maximal inhibitory concentration: 2900 nM
Beside the measured number, compound 4's estimate is 1.2-fold (0.08 log units) above it; measured number inside the range.
By their numbers in this assay, from the lowest: compounds 4, 2 and 3 (each within the scatter of the next). At a limit, above all of these: compound 1.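

In this assay, 4-methoxyphenyl on this oxygen gives a 1.6-fold lower number from compound 3 to compound 4 (0.21 log units; within the scatter) and a 1.2-fold lower number from compound 2 to compound 4 (0.07 log units; within the scatter). The place therefore now carries a six-membered aromatic ring of carbon only, as well as the two non-aromatic groups, and the numbers of compound 2, compound 3 and compound 4 remain unseparated, even with the larger group and its added hydrogen-bond acceptor. No measured property bears on these steps.

From the compounds shown here alone, whether any group on this oxygen can move the number beyond the scatter remains open. A plain phenyl would test the methoxy of the 4-methoxyphenyl group, while an amine or a carboxylic acid at the end of a longer chain would test a quite different kind of group at this place.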